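Swapping a triazole thioether for a tosylate on the sugar chain

This account rests on a few compounds, and the source may have more. Where it says the series, first, only, none or still open, it means among the compounds named here.

Compound 1 `O=[N+]([O-])c1ccc(-c2nc(CO[C@@H]3O[C@H](CO)[C@H]4OC5(CCCC5)O[C@@H]34)no2)cc1`: 15000 nM
Compound 2 `Nc1nnc(SC[C@H]2O[C@@H](OCc3noc(-c4ccc([N+](=O)[O-])cc4)n3)[C@@H]3OC4(CCCC4)O[C@@H]32)s1`: 28000 nM
Compound 3 `O=[N+]([O-])c1ccc(-c2nc(CO[C@@H]3O[C@H](CSc4ncn[nH]4)[C@H]4OC5(CCCC5)O[C@@H]34)no2)cc1`: 20000 nM

In a functional assay on HeLa cells (Homo sapiens) for antiproliferative activity, read by sulforhodamine B assay, with a stated time of 48 h (a lower number here means a stronger inhibitor of growth, a higher number a weaker inhibitor of growth), compound 3 gives 20000 nM, the second highest of the measured numbers; its nearest neighbour is compound 1 and its furthest is compound 2, and both gaps lie within the scatter. The unmeasured compound 4 `Cc1ccc(S(=O)(=O)OC[C@H]2O[C@@H](OCc3noc(-c4ccc([N+](=O)[O-])cc4)n3)[C@@H]3OC4(CCCC4)O[C@@H]32)cc1` differs from compound 3 in one place: ((4-methylphenyl)sulfonyl)oxy in place of (1H-1,2,4-triazol-5-yl)sulfanyl on a saturated chain carbon bound to a saturated ring carbon. Going by the values given here, no measured step puts this sulfonyl ester in place of the triazole thioether, so the closest guidance comes from the steps that altered the same chain carbon: a 1.3-fold higher number from compound 1 to compound 3 (0.12 log units; within the scatter) and a 1.9-fold higher number from compound 1 to compound 2 (0.27 log units; within the scatter), with a 1.4-fold lower number from compound 2 to compound 3 (0.15 log units; within the scatter) between the two thioethers. All of these stay within the scatter, so changes at this position have so far left this assay nearly unmoved. On that basis the step of a 1.1-fold lower number from compound 3 to compound 4 (0.05 log units; within the scatter) is expected to stay within the scatter, with no clear direction. Compound 4 is therefore estimated at 18000 nM, with a likely range from 6000 nM to 50000 nM.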

Compound 4, concentration for 50% growth inhibition: > 100000 nM
Compound 4 ended at the assay's limit; the forecaster's own chance of this, stated with the estimate: 10%; at least 5.5-fold (0.74 log units) between middle value and limit.
By their numbers in this assay, from the lowest: compounds 1, 3 and 2 (each within the scatter of the next). At a limit, above all of these: compound 4.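

In this assay compound 4 gives > 100000 nM, which is a limit of the assay and not a number. Putting ((4-methylphenyl)sulfonyl)oxy on this chain carbon gives an at least 5.0-fold higher number from compound 3 to compound 4 (0.69 log units; beyond the scatter) against the triazole thioether, an at least 3.5-fold higher number from compound 2 to compound 4 (0.55 log units; beyond the scatter) against the thiadiazole thioether, and an at least 6.6-fold higher number from compound 1 to compound 4 (0.82 log units; beyond the scatter) against the free hydroxy. The hydroxy and the two thioethers had stayed within the scatter of one another, so these steps are the first sign among the compounds shown that this chain carbon is not indifferent to what it carries, and they all point towards weaker growth inhibition.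

On these data alone, how far the true value of compound 4 lies past the limit stays open. So does whether the sulfonyl ester or the carbon-only aromatic ring matters more, which a phenylsulfanyl or a methanesulfonyloxy group on the same carbon could separate.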